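Replacing 4-fluoro-3-methylphenyl in a Growth Inhibitor

The compounds below may be only part of what the source reports. "The series", "measured", "known", "first", "only" and "open" are said of these compounds alone.

Of the compounds shown here, two have been tested so far in a functional assay on MCF-A cells (Homo sapiens) for cytotoxicity (a lower number here means a stronger inhibitor of growth, a higher number a weaker inhibitor of growth), on these cells. Compound 1 `COc1ccc(C2=C(c3cc(OC)c(OC)c(OC)c3)CC3CCCN3C2=O)cc1O` gives > 100000 nM in this assay and this result is a limit, not a number. Within the data shown here, compound 2 `CSc1ccc(C2=C(c3ccc(F)c(C)c3)C(=O)N3CCCC3C2)cc1` gives 500 nM as its result, and that is the only real number available, so it is the sole anchor for what follows.

Compound 3 `CSc1ccc(C2=C(c3ccc(SC)cc3)C(=O)N3CCCC3C2)cc1` keeps the shared core of compound 2 and carries 4-(methylsulfanyl)phenyl in place of 4-fluoro-3-methylphenyl on a double-bonded ring carbon, next to the ring atom that already bears a 4-(methylsulfanyl)phenyl group. The counted difference is 4-(methylsulfanyl)phenyl in place of 4-fluoro-3-methylphenyl on a double-bonded ring carbon and nothing else changes.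

Among the measured compounds shown here, no measured pair shows what a swap of this kind does, so only a rough guess is possible. The expected change is a 1.8-fold higher number from compound 2 to compound 3 (0.26 log units; within the scatter) as an estimate, a small step toward weaker growth inhibition that stays close to the usual scatter. Compound 3 is expected to give 900 nM in this assay with an estimated range from 150 nM to 6000 nM for a measurement.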

Compound 3, concentration for 50% growth inhibition: 8000 nM
Compound 3: the middle estimate sits 8.9-fold (0.95 log units) below what was measured; the whole stated range lies below it.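

In this assay, among these compounds, the change to 4-(methylsulfanyl)phenyl in place of 4-fluoro-3-methylphenyl on a double-bonded ring carbon gives a 16-fold higher number from compound 2 to compound 3 (1.20 log units; beyond the scatter) and this is the only measured step at this position, so the position clearly responds to what is placed there. The leaving and entering groups match in heavy-atom count and in their aromatic carbon ring, which shows that a match in those counts does not keep the growth inhibition of compound 2; what differs is sulfur in place of fluorine, the arrangement of the substituents on the ring, and the hydrogen-bond acceptor counted on the entering group. Compound 1 gives a limit, not a number, and it differs from the others in more than one place, so it adds nothing to this step: the limit of > 100000 nM in this assay, at which 1 of the 3 values shown sits.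

This single pair cannot separate the departure of the fluorine from that of the methyl or from the arrival of the methylsulfanyl group, and the data give no reason for the step. As far as these compounds go, how a plain phenyl, an amine or a carboxylic acid would fare on this carbon stays open.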